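Swapping a Trifluoromethoxy Group for Trifluoromethyl

The source may report more compounds than this note shows. Statements on the series, on what has been measured and on what is new or still open speak of the compounds shown alone.

Measured so far in an assay on mitochondria from L6 cells (Rattus norvegicus) for activation, with a stated time of 90 min; a higher number here means that more compound is needed for the effect, a lower number that less compound is needed:
- compound 1, `Cc1ccccc1Nc1nc2nonc2nc1Nc1ccccc1F`, gives 1100 nM
- compound 2, `CCOc1ccccc1Nc1nc2nonc2nc1Nc1ccccc1F`, gives 5600 nM
- compound 3, `Fc1ccccc1Nc1nc2nonc2nc1Nc1ccccc1OC(F)(F)F`, gives 1700 nM

Compound 3 holds the second highest of the three numbers. Its nearest neighbour is compound 1, a step that lies within the scatter, while compound 2 sits furthest away, a step beyond the scatter: a 3.3-fold lower number from compound 2 to compound 3 (0.52 log units; beyond the scatter).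

Compound 4 is `Fc1ccccc1Nc1nc2nonc2nc1Nc1ccccc1C(F)(F)F`. The change from compound 3 to compound 4 is trifluoromethyl in place of trifluoromethoxy on an aromatic carbon, placed on an aromatic carbon of a six-membered aromatic ring of carbon only, ortho to a large group.

Among the measured compounds shown here, no measured step makes exactly this change. The closest guides are the steps at the same place: a 3.3-fold lower number from compound 2 to compound 3 (0.52 log units; beyond the scatter), where a trifluoromethyl replaced an ethyl on an oxygen on an aromatic ring; a 1.5-fold higher number from compound 1 to compound 3 (0.19 log units; within the scatter), where trifluoromethoxy replaced methyl and the number hardly moved; and a 5.1-fold higher number from compound 1 to compound 2 (0.71 log units; beyond the scatter). These show that the fluorinated groups at this place have given numbers close to that of compound 1, whereas the ethoxy of compound 2 gave a clearly higher one. Since trifluoromethyl keeps the three fluorines and only drops the oxygen, compound 4 is expected to stay near compound 3, with a step of a 1.3-fold lower number from compound 3 to compound 4 (0.12 log units; within the scatter) within the scatter. The estimate for compound 4 in this assay is 1300 nM, expected to fall between 500 nM and 3500 nM.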

Compound 4, half-maximal effective concentration: 1400 nM
Beside the measured number, compound 4's estimate is 1.1-fold (0.03 log units) below it; the range from low to high includes it.
By their numbers in this assay, from the lowest: compounds 1, 4 and 3 (each within the scatter of the next); then compound 2.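

Among the compounds shown here, at this place on the ring, the result gives the first comparison of trifluoromethyl with trifluoromethoxy in this assay, and the two groups cannot be told apart (a 1.2-fold lower number from compound 3 to compound 4 (0.08 log units; within the scatter)), so the oxygen joining the three-fluorine group to the ring makes no difference that can be read here. The new compound also cannot be told apart from the methyl compound (a 1.3-fold higher number from compound 1 to compound 4 (0.10 log units; within the scatter)), which means that methyl, trifluoromethoxy and trifluoromethyl now form a group of three whose numbers all lie within the scatter of one another. Ethoxy is the only one of the four groups that stands apart, and the new comparison confirms this with a step beyond the scatter (a 4.0-fold lower number from compound 2 to compound 4 (0.60 log units; beyond the scatter)), so a group with an oxygen on the ring is not enough on its own to give a higher number, as compound 3 also shows.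

Nothing available here explains why these groups give the numbers they do. The compounds shown also leave open how an amine, a carboxylic acid or a chain longer than ethoxy, such as propoxy, would read at this place.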